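The compounds below may be only part of what the source reports. "The series", "measured", "known", "first", "only" and "open" are said of these compounds alone.

Measured in an ADME assay on Vero cells (Chlorocebus sabaeus) for cytotoxicity; a higher number here means that more compound is tolerated, a lower number that less compound is tolerated:
- compound 1 `CC(=O)c1c(NC(C)C)[nH]c2c(C(F)(F)F)cc(Cl)cc2c1=O`: > 25000 nM, a limit
- compound 2 `CC(=O)c1c(Nc2ccc(F)cc2F)[nH]c2c(C(F)(F)F)cc(Cl)cc2c1=O`: 7300 nM

Going by the values given here, compound 2 stands at 7300 nM, the only actual number so far. Compound 3 `CC(=O)c1c(Nc2ccc(F)cc2F)[nH]c2c(F)cc(Cl)cc2c1=O` has fluoro in place of trifluoromethyl on an aromatic carbon. Among the compounds with values here, the only measured step, an at least 3.4-fold lower number from compound 1 to compound 2 (0.53 log units; beyond the scatter), replaces isopropyl with 2,4-difluorophenyl on a nitrogen, at another place, so it bears only indirectly and gives no size for this change. No step beyond the scatter is therefore expected in this assay. The expected change is a 1.2-fold higher number from compound 2 to compound 3 (0.09 log units; within the scatter). For compound 3 the estimate is 9000 nM, with an expected range from 3500 nM to 22000 nM.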

Compound 3, half-maximal cytotoxic concentration: > 25000 nM
Compound 3 was reported as a limit; the forecaster's own chance of this, stated with the estimate: 10%; middle value at least 2.7-fold (0.44 log units) from the limit.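

In this assay, going by these compounds alone, the earlier compounds differed only on the nitrogen; the aromatic carbon ortho to a fused ring now also proves able to move the number, with fluoro in place of trifluoromethyl giving an at least 3.4-fold higher number from compound 2 to compound 3 (0.53 log units; beyond the scatter) while the 2,4-difluorophenyl group stays in place. This step has only a lower bound, because the read-out of compound 3 is a limit: the limit of > 25000 nM in this assay, at which 2 of the 3 values shown sit.

On these data alone, how a methyl, a nitrile or a methoxy group on this carbon would compare remains open, as does whether the step would hold with isopropyl on the nitrogen.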